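The compounds below may be only part of what the source reports. "The series", "measured", "known", "first", "only" and "open" are said of these compounds alone.

Measured in an in vitro ADME assay on microsomes from liver (Homo sapiens) for pharmacokinetics, read by LC-MS, with a stated time of 10 min, tested at 1 uM; a lower number here means slower removal, a higher number faster removal of the compound:
- compound 1 `CN1C[C@H](C(=O)Nc2ccc(C3CC3)cc2)[C@@H](c2ccc(/C=C/C(=O)Nc3ccccc3N)cc2)C1`: 12 mL/min/kg
- compound 2 `Cc1cccc(NC(=O)[C@H]2CN(C)C[C@@H]2c2ccc(/C=C/C(=O)Nc3ccccc3N)cc2)c1`: 14 mL/min/kg
- compound 3 `CN1C[C@H](C(=O)Nc2ccc(F)cc2F)[C@@H](c2ccc(/C=C/C(=O)Nc3ccccc3N)cc2)C1`: 12 mL/min/kg

Compound 3 stands level with compound 1 at the digits reported, and compound 2 differs from the pair only within the scatter. Compound 4 `Cc1ccc(NC(=O)[C@H]2CN(C)C[C@@H]2c2ccc(/C=C/C(=O)Nc3ccccc3N)cc2)cn1` is the next to be read. Its structural change is 6-methylpyridin-3-yl in place of 2,4-difluorophenyl on an amide-type nitrogen.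

Going by the values given here, three measured steps bear on this change, all at that same amide-type nitrogen: a 1.2-fold higher number from compound 1 to compound 2 (0.07 log units; within the scatter), no change at the digits printed from compound 1 to compound 3 (within the scatter) and a 1.2-fold lower number from compound 2 to compound 3 (0.07 log units; within the scatter). Each lies within the scatter, so exchanging the group at this place has not yet moved the number in this assay. Among the compounds with values here, none of the measured compounds has a hetero atom in the ring at this place, however, so these steps cover the new ring only indirectly, and the expected range stays wide.

No direction can be favoured, and the expected size is none beyond the scatter, with a 1.1-fold higher number from compound 3 to compound 4 (0.03 log units; within the scatter) as the estimated step. The estimated value for compound 4 is 13 mL/min/kg, with an expected range of 7 mL/min/kg to 24 mL/min/kg.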

Compound 4, clearance: 8 mL/min/kg
Estimate against measurement, compound 4: 1.6-fold (0.21 log units) above, within the range that was stated.
By their numbers in this assay, from the lowest: compounds 4, 1, 3 and 2 (each within the scatter of the next).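

In this assay, 6-methylpyridin-3-yl is the only ring with a hetero atom among the groups on this amide-type nitrogen, and its steps read a 1.5-fold lower number from compound 3 to compound 4 (0.18 log units; within the scatter) and a 1.8-fold lower number from compound 2 to compound 4 (0.24 log units; within the scatter) and also a 1.5-fold lower number from compound 1 to compound 4 (0.18 log units; within the scatter). Each of these stays within the scatter, so the exchange of a carbon-only ring for this ring with a hetero atom does not separate compound 4 from the other three compounds, and the series now spans both kinds of ring without a step beyond the scatter. Nothing measured here offers an explanation for the size of these steps.

The compounds shown leave open whether a ring carrying an amine or a carboxylic acid on this nitrogen would move the number beyond the scatter. They also leave open what a longer chain in place of the ring would do here.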